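From Compound 1 to Compound 3: a Chain Becomes a Ring

The source may report more compounds than this note shows. Statements on the series, on what has been measured and on what is new or still open speak of the compounds shown alone.

Of the compounds shown here, two sharing one core have been measured in a functional assay on MCF7 cells (Homo sapiens) for inhibition, read by MTT assay, with a stated time of 48 h; a lower number here means a stronger inhibitor, a higher number a weaker inhibitor. Compound 1 `CCOC(=O)C1=C(N/N=C(/C#N)C(=O)OCC)Nc2[nH]nc(C)c2C1c1ccc(N(C)C)cc1` gives 35600 nM and stands highest of the two numbers, so it is the weaker inhibitor of the pair. Compound 2 `CCOC(=O)C1=C(N/C=N/c2ncc(-c3ccccc3)s2)Nc2[nH]nc(C)c2C1c1ccc(N(C)C)cc1` gives 10100 nM, a lower number that lies beyond the usual scatter. Compound 3 `CCOC(=O)C1=C(N/C=N/c2ccc(C)cc2)Nc2[nH]nc(C)c2C1c1ccc(N(C)C)cc1` has not yet been measured. It differs from compound 1 in one place: a group of 9 heavy atoms (8 carbon, 1 nitrogen; one six-membered aromatic ring of carbon only) in place of a group of 9 heavy atoms (5 carbon, 2 nitrogen, 2 oxygen; no ring), on an amine nitrogen. Among the compounds with values here, no measured pair shows exactly this change, so the size of the step is uncertain, and the only hint is that compound 2 reaches a lower number with 10100 nM. Compound 3 is therefore expected to give 15000 nM, within a range of 5000 nM to 45000 nM. The step of a 2.4-fold lower number from compound 1 to compound 3 (0.38 log units; beyond the scatter) is expected to be a modest gain, possibly just beyond the scatter, although a change no larger than the scatter cannot be excluded.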

Compound 3, half-maximal inhibitory concentration: 50500 nM
Compound 3: middle estimate off by 3.4-fold (0.53 log units), on the low side; the whole stated range lies below it.
By their numbers in this assay, from the lowest: compound 2; then compounds 1 and 3 (each within the scatter of the next).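

In this assay, a group with one six-membered aromatic ring of carbon only, placed on the amine nitrogen in place of a ringless group of equal heavy-atom count, gives a 1.4-fold higher number from compound 1 to compound 3 (0.15 log units; within the scatter), so a ring in itself brings no gain here. On the double-bonded nitrogen, 4-methylphenyl in place of 5-phenyl-1,3-thiazol-2-yl gives a 5.0-fold higher number from compound 2 to compound 3 (0.70 log units; beyond the scatter), which shows that the identity of the group at this place can move the number and that a benzene-type ring does not match the group in compound 2. Nothing available here explains either step.

From the compounds shown here alone, it remains open whether the thiazole ring or its phenyl accounts for the lower number of compound 2. A plain 1,3-thiazol-2-yl would address that, and an amine or a carboxylic acid in place of the methyl of 4-methylphenyl would probe the other end of the group.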